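Compound 3 Against Its Furan-Bearing Neighbours

This account rests on a few compounds, and the source may have more. Where it says the series, first, only, none or still open, it means among the compounds named here.

Measured in a functional assay on HeLa S3 cells (Homo sapiens) for antiproliferative activity, read by XTT assay, with a stated time of 72 h; on this read-out higher numbers stand for weaker inhibition and lower numbers for stronger inhibition:
Compound 1 `Nc1nc2c(c(-c3ccco3)cn2[C@@H]2O[C@H](CO)[C@@H](O)[C@H]2O)c(=O)[nH]1`: > 20000 nM (a limit)
Compound 2 `Nc1nc2c(c(-c3ccoc3)cn2[C@@H]2O[C@H](CO)[C@@H](O)[C@H]2O)c(=O)[nH]1`: 10700 nM

Among the measured compounds shown here, compound 2 holds the only actual number in this assay, at 10700 nM. Compound 1 gives no number but a limit: the limit of > 20000 nM in this assay, at which 1 of the 2 values shown sits.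

Compound 3 `Nc1nc2c(c(-c3cccs3)cn2[C@@H]2O[C@H](CO)[C@@H](O)[C@H]2O)c(=O)[nH]1` has not yet been measured. It carries thiophen-2-yl in place of furan-3-yl on an aromatic carbon of the shared core: thiophen-2-yl in place of furan-3-yl on an aromatic carbon. For the measured compounds named here, one measured step bears on this change, the swap of furan-2-yl for furan-3-yl: an at least 1.8-fold lower number from compound 1 to compound 2 (0.27 log units; that floor lies within the scatter). Going by the values given here, no measured compound carries thiophen-2-yl, so that step offers only indirect guidance. Given this small step, the expected change in this assay stays within the scatter, with no clear direction: a 1.1-fold higher number from compound 2 to compound 3 (0.05 log units; within the scatter) is the estimated step. Compound 3 is expected at 12000 nM, with an estimated range of 4000 nM to 25000 nM.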

Compound 3, half-maximal inhibitory concentration: > 20000 nM
Compound 3: a limit, no number; the forecaster's own chance of this, stated with the estimate: 35%; middle value at least 1.6-fold (0.22 log units) from the limit.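

In this assay, thiophen-2-yl in place of furan-3-yl on this aromatic carbon gives an at least 1.8-fold higher number from compound 2 to compound 3 (0.27 log units; that floor lies within the scatter). Compound 3 gives a limit, not a number, so its step shows only a floor, and that floor does not separate the change from the usual scatter. The step between compound 1 and compound 3 cannot be read, and the limit is now the more frequent result among the groups tried on this carbon: the limit of > 20000 nM in this assay, at which 2 of the 3 values shown sit.

The compounds shown leave open how far compound 3 actually lies from compound 2, and whether compound 1 and compound 3 differ at all. They also leave open whether a phenyl ring or an amine on this aromatic carbon would give a number in this assay rather than a limit.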